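Moving the amide of compound 3 to an oxolane

The compounds below may be only part of what the source reports. "The series", "measured", "known", "first", "only" and "open" are said of these compounds alone.

Measured in a functional assay on MIA PaCa-2 cells (Homo sapiens) for inhibition, read by MTT assay, with a stated time of 3 days; a lower number here means a stronger inhibitor, a higher number a weaker inhibitor:
compound 1 `O=C([C@@H]1CCCN(S(=O)(=O)c2ccc(S(=O)(=O)N3CC[C@@H](O)C3)cc2)C1)N1CCC(F)(F)CC1`: 135 nM
compound 2 `CC(C)S(=O)(=O)c1ccc(S(=O)(=O)N2CCC[C@@H](C(=O)N3CCC(F)(F)CC3)C2)cc1`: 9.1 nM
compound 3 `CCN(CC)S(=O)(=O)c1ccc(S(=O)(=O)N2CCC[C@@H](C(=O)N3CCOCC3)C2)cc1`: 160 nM

Compound 3, at 160 nM, lies within the usual scatter of compound 1, at 135 nM. Both numbers stand well above that of compound 2, at 9.1 nM, so compound 3 belongs with the weaker inhibitors of this small set.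

Compound 4 `CCN(CC)S(=O)(=O)c1ccc(S(=O)(=O)N2CCC[C@@H](C(=O)N[C@@H]3CCOC3)C2)cc1` has (oxolan-3-yl)amino in place of morpholin-4-yl on a carbonyl carbon.

Among the compounds with values here, only one measured step exists, and it is large: a 15-fold lower number from compound 1 to compound 2 (1.17 log units; beyond the scatter). That step, however, puts isopropyl in place of 3-hydroxypyrrolidin-1-yl on a sulfonyl sulfur, not on the carbonyl carbon, so its size cannot be carried over. Within the data shown here, none of the measured compounds carries (oxolan-3-yl)amino. With no evidence for either direction, no step beyond the scatter is expected, and the estimate starts from compound 3 at 160 nM. The expected change is a 1.3-fold higher number from compound 3 to compound 4 (0.10 log units; within the scatter). For compound 4 the estimated value is 200 nM, with an expected range from 50 nM to 700 nM.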

Compound 4, half-maximal inhibitory concentration: 100 nM
Estimate against measurement, compound 4: 2.0-fold (0.30 log units) above; measured number inside the range.
By their numbers in this assay, from the lowest: compound 2; then compounds 4, 1 and 3 (each within the scatter of the next).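

In this assay, within the data shown here, the change on this carbonyl carbon gives a 1.6-fold lower number from compound 3 to compound 4 (0.20 log units; within the scatter), the first measured step at this position, and it stays within the usual scatter. Replacing the six-membered morpholin-4-yl ring with (oxolan-3-yl)amino therefore leaves the number effectively unchanged, even though the new group has a five-membered ring, the amide hydrogen as a hydrogen-bond donor and a defined stereocentre. Nothing available here explains this outcome or separates the contributions of those three differences.

The compounds shown leave open whether the opposite stereocentre on the oxolan-3-yl group would give a similar number. They also leave open whether a piperazin-1-yl ring or an open ethylamino chain on the same carbonyl carbon would stay within the scatter.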